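The compounds below may be only part of what the source reports. "The series", "measured", "known", "first", "only" and "open" are said of these compounds alone.

Measured compounds:
compound 1 `COc1cc(C)cc(-c2c(-c3ccnc(-c4ccc(C(C)=O)cc4)c3)cnn2CC#N)c1` — 93%
compound 2 `COc1cc(C)cc(-c2nn(CC#N)cc2-c2ccc(-c3cccc(C(C)=O)c3)nc2)c1` — 94%
compound 3 `Cc1cc(O)cc(-c2nn(CC#N)cc2-c2ccnc(-c3ccc(N(C)C)cc3)c2)c1` — 96%

In a functional assay on CCRF-CEM cells (Homo sapiens) for cytotoxicity, read by sulforhodamine B assay, with a stated time of 48 h, tested at 0.01 uM (a higher number here means a weaker effect of the compound at the concentration tested, a lower number a stronger effect), compound 1 gives 93%. This number sits at the low end of the three, but the gap to compound 2 and the gap to compound 3 both lie within the usual scatter, so no ordering among the three can be claimed; at this concentration each of them leaves the cells largely untouched.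

The step under consideration goes from compound 1 to compound 4 `COc1cc(C)cc(-c2c(-c3ccnc(-c4ccc(N(C)C)cc4)c3)cnn2CC#N)c1`, which has not yet been measured in this assay. The difference is dimethylamino in place of acetyl on an aromatic carbon. Among the compounds with values here, no pair among the measured compounds shows this single change in isolation, so the step cannot be read off directly. What is available is compound 3, which also carries a dimethylamino group on its outer ring and gives 96% in this assay, a number within the scatter of compound 1.

On that basis the step of a number 1 percentage points higher from compound 1 to compound 4 (within the scatter) is expected to be none beyond the scatter. Compound 4 is therefore estimated to give 94% in this assay, with a range from 84% to 100%.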

Compound 4, a percentage reported as activity, at one concentration (the size of the read-out at that concentration, not a potency): 73%
For compound 4 the middle estimate is 21 percentage points above the measured one; measured number outside the range, below it.
By their numbers in this assay, from the lowest: compound 4; then compounds 1, 2 and 3 (each within the scatter of the next).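

Replacing 4-acetylphenyl with 4-(dimethylamino)phenyl on the core of compound 1 gives a number 20 percentage points lower from compound 1 to compound 4 (beyond the scatter) in this assay. Within the data shown here, this is the first change to move the read-out beyond the scatter, so the group on this six-membered carbon ring, para to a large group, does matter for the effect on these cells. The two groups have the same number of heavy atoms and the same count of hydrogen-bond acceptors, so those counts alone do not separate them, and nothing measured here explains the difference in effect.

The compounds shown leave open whether the gain belongs to dimethylamino in particular or would also appear with another amine at this place, such as a plain amino group, diethylamino or morpholine, and whether a carboxylic acid would behave like acetyl. Compound 3 also carries dimethylamino but differs from compound 4 in more than one place, so it cannot show whether the gain depends on the rest of the molecule, and a read-out at a single concentration gives no potency for compound 4.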